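The source may report more compounds than this note shows. Statements on the series, on what has been measured and on what is new or still open speak of the compounds shown alone.

Working notes on the series, tested in a functional assay on SF-295 cells (Homo sapiens) for inhibition, with a stated time of 48 h; a lower number here means a stronger inhibitor of growth, a higher number a weaker inhibitor of growth:

- compound 1 `COc1ccccc1/C=C/C(=O)c1c(O)cc2occc2c1OC`: 16600 nM
- compound 2 `COc1c(C(=O)/C=C/c2ccc(Cl)cc2)c(O)c(Br)c2occc12`: 6670 nM
- compound 3 `C=CCc1c(O)c(C(=O)/C=C/c2ccccc2)c(OC)c2ccoc12`: 2440 nM

Compound 3 has the lowest number of the three, and its gaps to compound 2 and compound 1 both lie beyond the scatter. The next compound to test is compound 4 `C=CCc1c(O)c(C(=O)/C=C/c2ccc(Cl)cc2)c(OC)c2ccoc12`, which keeps the structure of compound 3 except for one change: chloro in place of hydrogen on an aromatic carbon, para to a large group, so that phenyl becomes 4-chlorophenyl (chloro in place of hydrogen on an aromatic carbon).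

Within the data shown here, no measured pair isolates this change. Compound 2 already carries the 4-chlorophenyl group and gives 6670 nM, but it also differs from compound 3 elsewhere on the shared core, so its gap to compound 3 cannot be assigned to the chloro group. Among the measured compounds shown here, with no measured step to guide the size or direction, the working expectation is no shift beyond the scatter, with wide margins on either side. The expected change, a 1.1-fold lower number from compound 3 to compound 4 (0.03 log units; within the scatter), is only an estimate. For compound 4 the estimated value in this assay is 2300 nM, with an expected range from 800 nM to 6700 nM.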

Compound 4, concentration for 50% growth inhibition: 2770 nM
Compound 4: the middle estimate sits 1.2-fold (0.08 log units) below what was measured, and the stated range covers the measured number.
By their numbers in this assay, from the lowest: compounds 3 and 4 (each within the scatter of the next); then compound 2; then compound 1.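

In this assay, among these compounds, the first pair to isolate chloro in place of hydrogen on an aromatic carbon, para to a large group, gives a 1.1-fold higher number from compound 3 to compound 4 (0.06 log units; within the scatter), so phenyl and 4-chlorophenyl cannot be told apart in this pair. With the 4-chlorophenyl group held in place, allyl in place of bromo on an aromatic carbon gives a 2.4-fold lower number from compound 2 to compound 4 (0.38 log units; beyond the scatter), a modest step beyond the scatter, and this is the one single change shown so far that moves the number beyond the scatter. No measurement is available that bears on the reason for the size of either step.

The compounds shown leave open whether other groups at the para place, such as methoxy, an amine or a carboxylic acid, would also stay within the scatter of compound 3, and whether a propyl chain or a plain hydrogen in place of allyl would match compound 4. Going by these compounds, the chloro result also rests on a single pair, so whether it holds with bromo in place of allyl remains open.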